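This account rests on a few compounds, and the source may have more. Where it says the series, first, only, none or still open, it means among the compounds named here.

Going by the values given here, compound 1, `O=C(Nc1ccccc1C(F)(F)F)C1CCc2ccccc2N1C(=O)c1ccccc1Cl`, stands at the low end of the three numbers so far. In a functional assay on PC-3 cells (Homo sapiens) for cytotoxicity, read by sulforhodamine B assay, with a stated time of 72 h (a higher number here means a weaker inhibitor of growth, a lower number a stronger inhibitor of growth), compound 1 gives 5140 nM. Its nearest neighbour is compound 3, `CCCC(=O)N1c2ccccc2CCC1C(=O)Nc1cc(C(F)(F)F)cc(C(F)(F)F)c1`, which in this assay gives 18600 nM; furthest is compound 2, `O=C(Nc1ccccc1O)C1CCc2ccccc2N1C(=O)c1ccccc1Cl`, which in this assay gives 60000 nM. Among the compounds with values here, the one measured step, a 12-fold higher number from compound 1 to compound 2 (1.07 log units; beyond the scatter), concerns the anilide ring and not the acyl group.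

Compound 4, `CC(=O)N1c2ccccc2CCC1C(=O)Nc1ccccc1C(F)(F)F`, differs from compound 1 by methyl in place of 2-chlorophenyl on a carbonyl carbon. Within the data shown here, no measured step bears directly on this change. Among the measured compounds shown here, compound 3 carries a short alkyl acyl group, as compound 4 does, but also a different anilide, so its two values with compound 1 cannot be separated into one cause; they show only that the alkyl-acyl compound 3 sits higher than compound 1 in this assay.

The step from compound 1 to compound 4 is therefore expected to be a 3.9-fold higher number from compound 1 to compound 4 (0.59 log units; beyond the scatter), towards a higher number. Compound 4 is expected to give about 20000 nM, within 6000 nM to 60000 nM.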

Compound 4, concentration for 50% growth inhibition: > 80000 nM
Compound 4 gave a limit, no number; the forecaster's own chance of this, stated with the estimate: 15%; at least 4.0-fold (0.60 log units) between middle value and limit.
By their numbers in this assay, from the lowest: compound 1; then compound 3; then compound 2. At a limit, above all of these: compound 4.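

Going by these compounds alone, with the anilide held constant, the first measured change at this acyl position is large: an at least 15-fold higher number from compound 1 to compound 4 (1.19 log units; beyond the scatter). In this assay, within the data shown here, compound 4 reaches a limit of the assay and gives no number: the limit of > 80000 nM in this assay, at which 1 of the 4 values shown sits. The earlier compounds could not separate the acyl group from the anilide, but this pair shows that growth inhibition depends on the acyl group as well, with the methyl compound failing to give a measurable value where the 2-chlorophenyl compound does.

On these data alone, it remains open whether a phenyl group without the chlorine, a hexanoyl chain, or an acyl group bearing an amine would sit nearer to compound 1 or to compound 4. As far as these compounds go, with only a limit for compound 4, the full size of this step also remains unknown.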